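Triazole-linked trimethoxyphenyl series: chloro for methoxy

The source may hold more compounds than are shown below. What is called first, only, known or untested is meant among the compounds shown, and "the series" means these compounds.

Compound 1 `COc1ccc(-n2ncnc2-c2cc(OC)c(OC)c(OC)c2)cc1` carries a methoxy group on the phenyl ring attached to the shared core. In a functional assay on A549 cells (Homo sapiens) for antiproliferative activity, read by MTT assay, with a stated time of 72 h (on this read-out lower numbers stand for stronger inhibition and higher numbers for weaker inhibition), compound 1 gives only a limit of the assay, > 10000 nM, and not a measured number. Compound 2 `CCOc1ccccc1-c1ncnn1-c1cc(OC)c(OC)c(OC)c1` likewise reaches only the limit, > 10000 nM, in this assay. Compound 3 `COc1cc(-n2ncnc2-c2ccc(OC(F)(F)F)cc2)cc(OC)c1OC` also stops at the limit, > 10000 nM, in this assay. All three values therefore share (the limit of > 10000 nM in this assay, at which 3 of the 3 values shown sit), so compound 1 cannot be placed above or below either companion; nothing in the numbers shown separates it from them.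

The unmeasured analogue compound 4 `COc1cc(-c2ncnn2-c2ccc(Cl)cc2)cc(OC)c1OC` differs from compound 1 by chloro in place of methoxy on an aromatic carbon. For the measured compounds named here, no pair of measured compounds isolates such a change, so no measured step is available for it. Given that the three measured compounds sit at the same limit, a step from compound 1 to compound 4 in this assay is not expected to move beyond the usual scatter. Compound 4 is estimated at 15000 nM, with a range from 4000 nM to 60000 nM, an expected shift of a step that the limit leaves unreadable from compound 1 to compound 4.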

Compound 4, half-maximal inhibitory concentration: > 10000 nM
Compound 4: only a limit was reported; the forecaster's own chance of this, stated with the estimate: 70%; the middle value does not contradict the limit.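

In this assay compound 4 gives > 10000 nM, which is a limit and not a number. The change from compound 1 to compound 4 therefore yields no readable step: the limit of > 10000 nM in this assay, at which 4 of the 4 values shown sit. The compounds shown leave open what chloro in place of methoxy does to activity on a measured value.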